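Trimming the sulfur substituent: from compound 3 to compound 4

A few compounds are considered here, and "the series" means these few. Any claim that something is new, unique, unknown or untested is made for them only; others in the source may bear on it.

Compound 1 `CCCCCSCCC1C2CCC(O2)C1C/C=C\CCCC(=O)O`: 37000 nM
Compound 2 `O=C(O)CCC/C=C\CC1C2CCC(O2)C1CSCC1CCCCC1`: 20000 nM
Compound 3 `CCCCCC(C)SCC1C2CCC(O2)C1C/C=C\CCCC(=O)O`: 3800 nM

In a functional assay on a cell-free system (plasma) with thromboxane A2 receptor (Homo sapiens) as the target (a lower number here means a stronger inhibitor, a higher number a weaker inhibitor), compound 3 gives the lowest of the three numbers; the step of a 9.7-fold lower number from compound 1 to compound 3 (0.99 log units; beyond the scatter) and the step of a 5.3-fold lower number from compound 2 to compound 3 (0.72 log units; beyond the scatter) both lie beyond the scatter. Compound 4 `CSCC1C2CCC(O2)C1C/C=C\CCCC(=O)O` differs from compound 3 by methyl in place of 1-methylhexyl on a sulfur. The two steps that bear on this change, a 9.7-fold lower number from compound 1 to compound 3 (0.99 log units; beyond the scatter) and a 5.3-fold lower number from compound 2 to compound 3 (0.72 log units; beyond the scatter), both moved the number downward when a larger group replaced a smaller one on the same sulfur. Going the other way, to the smallest group in the set, a step upward beyond the scatter is expected, a 21-fold higher number from compound 3 to compound 4 (1.32 log units; beyond the scatter), and the number for compound 4 is estimated at 80000 nM, with a range from 20000 nM to 300000 nM.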

Compound 4, half-maximal inhibitory concentration: 38000 nM
Beside the measured number, compound 4's estimate is 2.1-fold (0.32 log units) above it; the measured number falls inside the stated range.
By their numbers in this assay, from the lowest: compound 3; then compounds 2, 1 and 4 (each within the scatter of the next).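

In this assay, the step back to methyl on this sulfur, a 10-fold higher number from compound 3 to compound 4 (1.00 log units; beyond the scatter), shows that the low number of compound 3 is lost when the 1-methylhexyl group goes. Size alone does not order this set, since methyl stands level with the larger groups, with a 1.9-fold higher number from compound 2 to compound 4 (0.28 log units; within the scatter) and a 1.0-fold higher number from compound 1 to compound 4 (0.01 log units; within the scatter); among these compounds, only the 1-methylhexyl compound stands apart. As far as these compounds go, whether a shorter branched group such as isopropyl, a phenyl ring or a longer branched chain on the sulfur would give a low number stays open. Nothing available explains why 1-methylhexyl stands apart.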